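Substituent on the ring nitrogen and ileum potency

The compounds below may be only part of what the source reports. "The series", "measured", "known", "first", "only" and "open" are said of these compounds alone.

Compound 2 `CN1CCN(c2nc3ccccc3[nH]2)CC1` carries only hydrogen on the aromatic nitrogen of the shared core. In a functional assay on ileum for inhibition of histamine H1 receptor (Cavia porcellus) (a higher number here means a weaker inhibitor, a lower number a stronger inhibitor), compound 2 reaches only the limit > 3000 nM, not a number. Compound 1 `CCCSCn1c(N2CCN(C)CC2)nc2ccccc21` bears (propylsulfanyl)methyl there, and in this assay compound 1 gives 68 nM; the step of an at least 44-fold higher number from compound 1 to compound 2 (1.64 log units; beyond the scatter) sits against (the limit of > 3000 nM in this assay, at which 1 of the 2 values shown sits). Compound 3 `CN1CCN(c2nc3ccccc3n2CCO)CC1` introduces (2-hydroxyethyl in place of hydrogen on an aromatic nitrogen). Among the measured compounds shown here, the one relevant step runs the other way with a different group, so a downward move smaller than an at least 44-fold higher number from compound 1 to compound 2 (1.64 log units; beyond the scatter) is expected for compound 3. Compound 3 is estimated at 1200 nM in this assay, range 200 nM to 6000 nM, a step of an at least 2.5-fold lower number from compound 2 to compound 3 (0.39 log units; beyond the scatter).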

Compound 3, half-maximal inhibitory concentration: 410 nM
The estimate for compound 3 lay 2.9-fold (0.47 log units) above the measured number, within the range that was stated.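

Placing 2-hydroxyethyl on the aromatic nitrogen in this assay also gives a gain over hydrogen (an at least 7.3-fold lower number from compound 2 to compound 3 (0.86 log units; beyond the scatter)), so the gain is not confined to (propylsulfanyl)methyl. The two substituents are not equivalent: hydroxymethyl in place of propylsulfanyl on the saturated chain carbon gives a weaker result (a 6.0-fold higher number from compound 1 to compound 3 (0.78 log units; beyond the scatter)). The gain over hydrogen has only a lower bound, since compound 2 stands at a limit and not a number: the limit of > 3000 nM in this assay, at which 1 of the 3 values shown sits.

As far as these compounds go, whether the chain itself or its end group sets the potency stays open. A terminal amine, a plain ethyl chain or a longer thioether chain on this nitrogen would separate the two.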